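A few compounds are considered here, and "the series" means these few. Any claim that something is new, unique, unknown or untested is made for them only; others in the source may bear on it.

Compound 1, `Cc1ccc(Nc2nc(C)c(C(=O)/C=C/c3ccccc3)s2)cc1`, was tested in a functional assay on Bel-7402 cells (Homo sapiens) for cytotoxicity, read by MTT assay; a higher number here means a weaker inhibitor, a lower number a stronger inhibitor. In this assay compound 1 gives > 25000 nM, which is a limit of the assay rather than a number. Compound 2, `Cc1ccc(Nc2nc(C)c(C(=O)/C=C/c3ccccc3Cl)s2)cc1`, carries chloro in place of hydrogen on an aromatic carbon. In this assay compound 2 gives > 25000 nM, again a limit and not a number. The step that the two limits leave unreadable from compound 1 to compound 2 therefore cannot be read, and the limit of > 25000 nM in this assay, at which 2 of the 2 values shown sit, is all that the two values show. Compound 3, `Cc1cccc(Nc2nc(C)c(C(=O)/C=C/c3ccccc3)s2)c1`, has not yet been measured. It differs from compound 1 by 3-methylphenyl in place of 4-methylphenyl on a nitrogen on an aromatic ring. Among the compounds with values here, no measured step bears on this change: the only step on record changes a different part of the molecule and is itself unreadable. Since compound 1 stands only at a limit, there is no firm number from which a step in this assay could be gauged, in either direction. Compound 3 is therefore expected to sit near the same limit, the step that the limit leaves unreadable from compound 1 to compound 3 being the estimate. The estimate for compound 3 is 35000 nM, within a range from 8000 nM to 150000 nM.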

Compound 3, half-maximal inhibitory concentration: > 25000 nM
Compound 3 was reported as a limit; the forecaster's own chance of this, stated with the estimate: 80%; the middle value lies beyond the limit too.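

Compound 1 and compound 3 both stand at a limit in this assay rather than at a number, so no step between them can be read, and all three compounds share the same result: the limit of > 25000 nM in this assay, at which 3 of the 3 values shown sit.

The compounds shown leave open how strong any of them really is in this assay, and whether 3-methylphenyl or 4-methylphenyl makes any difference.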